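A Thiophen-3-yl in Place of 4-Fluorophenyl: Expected Outcome

The compounds below may be only part of what the source reports. "The series", "measured", "known", "first", "only" and "open" are said of these compounds alone.

Within the data shown here, compound 2 `OC[C@H]1O[C@@H](n2cc(-c3ccc(F)cc3)nn2)[C@H](O)[C@@H]1O` is the only compound here with a number actually read: in a functional assay on L1210 cells (Mus musculus) (a lower number here means a stronger inhibitor, a higher number a weaker inhibitor), compound 2 gives 209000 nM. Compound 1 `OCc1cn([C@@H]2O[C@H](CO)[C@@H](O)[C@H]2O)nn1` differs from compound 2 by carrying a hydroxymethyl where compound 2 carries the 4-fluorophenyl. In this assay compound 1 gives > 200000 nM, which is a limit of the assay rather than a number. Accordingly the step that the limit leaves unreadable from compound 1 to compound 2 cannot be sized, as the limit of > 200000 nM in this assay, at which 1 of the 2 values shown sits, shows. Compound 3 `OC[C@H]1O[C@@H](n2cc(-c3ccsc3)nn2)[C@H](O)[C@@H]1O` is not yet measured; it differs from compound 2 by thiophen-3-yl in place of 4-fluorophenyl on an aromatic carbon. Among the measured compounds shown here, no measured step exchanges one aromatic ring for another, so the only guidance is that both measured compounds are very weak in this assay. For compound 3 the expectation is therefore a step of a 1.0-fold lower number from compound 2 to compound 3 (0.02 log units; within the scatter) of no size beyond the scatter. Compound 3 is estimated at 200000 nM, between 70000 nM and 600000 nM, with a real chance that this assay again reports only a limit.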

Compound 3, half-maximal inhibitory concentration: 182000 nM
For compound 3 the middle estimate is 1.1-fold (0.04 log units) above the measured one, and the stated range covers the measured number.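

In this assay, exchanging one aromatic ring for another at this position gives a 1.1-fold lower number from compound 2 to compound 3 (0.06 log units; within the scatter), so thiophen-3-yl and 4-fluorophenyl cannot be told apart here, even though a five-membered ring containing sulfur replaces a six-membered ring of carbon only. Putting thiophen-3-yl in place of hydroxymethyl gives an at least 1.0-fold lower number from compound 1 to compound 3 (0.04 log units; that floor lies within the scatter), and that floor does not show a real difference. This step is only a floor because compound 1 is read as a limit and not as a number: the limit of > 200000 nM in this assay, at which 1 of the 3 values shown sits.

As far as these compounds go, it remains open whether another kind of group on this aromatic carbon, such as an amine, a carboxylic acid or a longer alkyl chain, would move the number beyond the scatter. From the compounds shown here alone, it is also open whether a change elsewhere on the shared core would do so.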